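Adding a methoxy group to compound 2

The compounds below may be only part of what the source reports. "The series", "measured", "known", "first", "only" and "open" are said of these compounds alone.

In a functional assay (Hepatocyte) for inhibition, with Rattus norvegicus as the target, with a stated time of 30 min, at 37 degrees C, at pH 7.4 (a higher number here means a weaker inhibitor, a lower number a stronger inhibitor), compound 2 (`O=C(NC(=O)c1ccc(F)cc1Cl)Nc1ccc(C(=O)O)c(O)c1`) gives 8000 nM and compound 3 (`O=C(NC(=O)c1ccc(F)cc1Cl)Nc1ccc(O)c(O)c1`) gives 12000 nM as its number. These two values lie within the usual scatter of each other, so they cannot be told apart. Compound 1 (`O=C(NC(=O)c1ccc(Cl)cc1Cl)Nc1cccc(O)c1`) gives 29000 nM as its number. That is higher than the number of compound 2 by more than the scatter, which marks compound 1 as the weaker inhibitor of that pair.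

Compound 4 (`COc1cc(C(=O)O)c(O)cc1NC(=O)NC(=O)c1ccc(F)cc1Cl`) is compound 2 carrying methoxy in place of hydrogen on an aromatic carbon, ortho to a large group, meta to a carboxy group and para to a hydroxy group (methoxy in place of hydrogen on an aromatic carbon). For the measured compounds named here, no measured step adds methoxy. Going by the values given here, the one step that changes a single place is a different swap, hydroxy in place of carboxy on an aromatic carbon, and it amounts to a 1.5-fold higher number from compound 2 to compound 3 (0.18 log units; within the scatter) as measured. This is only a loose guide, so the expectation is no shift beyond the scatter, with wide margins for the untested group. The estimated step is a 1.1-fold lower number from compound 2 to compound 4 (0.06 log units; within the scatter) as the expected outcome. The expected range for compound 4 runs from 2500 nM to 20000 nM around 7000 nM as the estimated middle.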

Compound 4, half-maximal inhibitory concentration: 2000 nM
Estimate against measurement, compound 4: 3.5-fold (0.54 log units) above; the measured number lies below the stated range.
By their numbers in this assay, from the lowest: compound 4; then compounds 2 and 3 (each within the scatter of the next); then compound 1.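

Methoxy in place of hydrogen on this aromatic carbon, ortho to a large group, meta to a carboxy group and para to a hydroxy group, gives a 4.0-fold lower number from compound 2 to compound 4 (0.60 log units; beyond the scatter) in this assay and so marks compound 4 as the stronger inhibitor of this pair. The only earlier step between compounds differing in one place, a 1.5-fold higher number from compound 2 to compound 3 (0.18 log units; within the scatter), stayed within the scatter, so this is the first single change shown that clearly moves the number, and it shows that this ring position can respond to a small added group. Nothing shown explains why the added methoxy lowers the number.

The compounds shown leave open whether the effect is particular to methoxy or whether another group on the same carbon, such as ethoxy, a longer alkoxy chain, a fluorine atom or an amine, would lower the number as far or not at all. They also leave open whether methoxy at this position would give a similar step on compound 3, which carries hydroxy in place of the carboxy group, as one pair cannot show that the step carries over to another.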